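The source may report more compounds than this note shows. Statements on the series, on what has been measured and on what is new or still open speak of the compounds shown alone.

Measured so far in an ADME assay on CCRF-CEM cells (Homo sapiens) for antiproliferative activity, with a stated time of 48 h; on this read-out higher numbers stand for weaker inhibition and lower numbers for stronger inhibition:
compound 1 `C=C(Br)C(=O)Nc1ccc(/C=C/C(=O)c2ccccc2)cc1` gives 4000 nM
compound 2 `C=C(Br)C(=O)Nc1ccc(/C=C/C(=O)c2ccc(OC)cc2)cc1` gives 1400 nM
compound 3 `C=C(Br)C(=O)Nc1ccc(C(=O)/C=C/c2ccccc2OC)cc1` gives 580 nM

Compound 1 and compound 2 share one core; the change methoxy in place of hydrogen on an aromatic carbon gave a 2.9-fold lower number from compound 1 to compound 2 (0.46 log units; beyond the scatter). Compound 3 sits on another core, and the difference between the two cores is not broken down here; in this assay compound 3 stands lowest of the three numbers, beyond the scatter from both others.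

Compound 4 `C=C(Br)C(=O)Nc1ccc(C(=O)/C=C/c2ccc(OC)cc2OC)cc1` differs from compound 3 by methoxy in place of hydrogen on an aromatic carbon. Among the measured compounds shown here, this is the same kind of change as from compound 1 to compound 2, though not the same: the place in compound 4 is also meta to a methoxy group, and the core is not the one of compound 1. A lowering is expected, estimated at a 1.7-fold lower number from compound 3 to compound 4 (0.22 log units; within the scatter), held smaller than the earlier step because a 2.9-fold lower number from compound 1 to compound 2 (0.46 log units; beyond the scatter) came on a different core and place. For compound 4 the estimate is 350 nM, expected between 120 nM and 1000 nM.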

Compound 4, half-maximal inhibitory concentration: 1100 nM
The estimate for compound 4 lay 3.1-fold (0.50 log units) below the measured number; the measured number lies above the stated range.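

Methoxy in place of hydrogen on an aromatic carbon does not carry over as a fixed step between these two cores in this assay: the same change on two cores in this assay, a 2.9-fold lower number (0.46 log units; beyond the scatter) from compound 1 to compound 2 and a 1.9-fold higher number (0.28 log units; within the scatter) from compound 3 to compound 4, 5.4-fold (0.73 log units) apart, beyond the scatter of two such steps. On the core of compound 3 the step is a 1.9-fold higher number from compound 3 to compound 4 (0.28 log units; within the scatter), so the lowering seen on the core of compound 1 does not reappear there. The two pairs differ in both core and place of the methoxy, so they cannot show which of the two accounts for the gap.

Still open, going by these compounds, is whether methoxy at one matching place on both cores would give matching steps. Also open, on these data alone, is whether an amine or a carboxylic acid at these places would follow either step.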